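The source may hold more compounds than are shown below. What is called first, only, known or untested is meant among the compounds shown, and "the series" means these compounds.

Measured so far:
compound 1 `CCN(Cc1ccccn1)c1ccc(C(=O)N2CCc3ccc(OS(N)(=O)=O)cc3C2)cc1` — 87.7%
compound 2 `CCN(Cc1cccc(Br)c1)c1cccc(C(=O)N2CCc3ccc(OS(N)(=O)=O)cc3C2)c1` — 24.9%

In an assay on HEK293 cells for inhibition of Steryl-sulfatase (Homo sapiens), tested at 1 uM (on this read-out higher numbers stand for a stronger effect at the one concentration tested and lower numbers for a weaker effect), compound 1 gives the higher of the two numbers, and compound 2 sits lower by a gap beyond the scatter. The two differ in more than one place, so the gap cannot be assigned to a single change. Compound 3 `CCN(Cc1cccc(Br)c1)c1ccc(C(=O)N2CCc3ccc(OS(N)(=O)=O)cc3C2)cc1` is not yet measured; it shares the core of compound 1 and differs from it in one place: 3-bromophenyl in place of pyridin-2-yl on a saturated chain carbon bound to a nitrogen on an aromatic ring. Compound 2 also carries the 3-bromobenzyl group and gives only 24.9%, whereas compound 1 gives 87.7%. On that basis a drop beyond the scatter is expected, a number 22.7 percentage points lower from compound 1 to compound 3 (beyond the scatter). Compound 3 is expected near 65%, between 35% and 90%.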

Compound 3, a percentage reported as inhibition, at one concentration (the size of the read-out at that concentration, not a potency): 97.2%
The estimate for compound 3 lay 32.2 percentage points below the measured number, outside the stated range (above it).
By their numbers in this assay, from the lowest: compound 2; then compounds 1 and 3 (each within the scatter of the next).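

In this assay 3-bromophenyl in place of pyridin-2-yl on a saturated chain carbon bound to a nitrogen on an aromatic ring gives a number 9.5 percentage points higher from compound 1 to compound 3 (within the scatter) and so shows that this place accepts either ring. The pyridine nitrogen is therefore not required for a high number at this place, and the 3-bromobenzyl group alone does not account for the low number of compound 2. Nothing at hand explains this tolerance.

On these data alone, whether plain benzyl, 4-bromobenzyl or cyclohexylmethyl would hold up here remains open. Readings at one concentration also leave the potencies of compound 1 and compound 3 unresolved.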